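The compounds below may be only part of what the source reports. "The series", "measured", "known", "first", "only" and "open" are said of these compounds alone.

Series notes. Compound 1 `Cc1noc(-c2cc3ccccc3[nH]2)n1` in a functional assay on Jurkat cells (Homo sapiens) for antiproliferative activity, read by WST assay, with a stated time of 72 h (on this read-out lower numbers stand for stronger inhibition and higher numbers for weaker inhibition), reports only the limit of the assay, > 50000 nM. Compound 2 `Cc1noc(-c2cc3cc(F)ccc3[nH]2)n1` gives 22900 nM in this assay. Going by the values given here, the single measured change of one place is an at least 2.1-fold lower number from compound 1 to compound 2 (0.33 log units; beyond the scatter). Compound 3 `COc1ccc2[nH]c(-c3nc(-c4ccccc4)no3)cc2c1` likewise reports only a limit in this assay, > 50000 nM. Compound 3 thus stands with the limit of > 50000 nM in this assay, at which 2 of the 3 values shown sit, and no number is known for it. Compound 4 `Clc1ccc2[nH]c(-c3nc(-c4ccccc4)no3)cc2c1` differs from compound 3 by chloro in place of methoxy on an aromatic carbon. Among the compounds with values here, no measured step matches this exchange; the step from compound 1 to compound 2 also brought in a halogen and was at least modest, so a modest fall from compound 3 to compound 4 is expected, an at least 1.6-fold lower number from compound 3 to compound 4 (0.22 log units; that floor lies within the scatter). Compound 4 is estimated at 30000 nM, with a range of 8000 nM to 100000 nM, a limit remaining possible.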

Compound 4, half-maximal inhibitory concentration: > 50000 nM
Compound 4: only a limit was reported; the forecaster's own chance of this, stated with the estimate: 45%; middle value at least 1.6-fold (0.22 log units) from the limit.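

No step can be read from compound 3 to compound 4, because each reports only a limit: the limit of > 50000 nM in this assay, at which 3 of the 4 values shown sit. The compounds shown leave open whether chloro in place of methoxy on an aromatic carbon changes the read-out at all.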